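This account rests on a few compounds, and the source may have more. Where it says the series, first, only, none or still open, it means among the compounds named here.

Among the compounds with values here, compound 3 `CCCC1=C(N2CC2)C(=O)C(CCC)=C(N2CC2)C1=O` stands lowest of the three compounds measured so far: in a functional assay on L1210 cells (Mus musculus), with a stated time of 1 days (on this read-out lower numbers stand for lower potency and higher numbers for higher potency (the scale is a negative logarithm)), compound 3 gives 4.14. Compound 2 `CCC1=C(N2CC2)C(=O)C(C(COC(N)=O)OC)=C(N2CC2)C1=O` is nearest, and in this assay compound 2 gives 4.92, beyond the scatter above compound 3. Compound 1 `CC1=C(N2CC2)C(=O)C(CCCOC(N)=O)=C(N2CC2)C1=O` lies furthest away; in this assay compound 1 gives 5.48. Both higher compounds carry a carbamoyloxy group, which compound 3 lacks. Compound 4 `CCCC1=C(N2CC2)C(=O)C(CCOC(N)=O)=C(N2CC2)C1=O` differs from compound 3 by carbamoyloxy in place of methyl on a saturated chain carbon, two bonds along the chain from a double-bonded ring carbon. Within the data shown here, no measured step covers this change. A rise beyond the scatter is expected for the step of a number 0.96 log units higher from compound 3 to compound 4 (beyond the scatter). The expectation rests on compound 1 at 5.48 and compound 2 at 4.92, which both carry the entering group. Compound 4 is estimated at 5.1 in this assay, with a range from 4.5 to 5.7.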

Compound 4, logarithm of the reciprocal of the active concentration, log(1/C): 4.42
Compound 4: the middle estimate sits 0.68 log units above what was measured; measured number outside the range, below it.
By their numbers in this assay, from the lowest: compounds 3 and 4 (each within the scatter of the next); then compound 2; then compound 1.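

Carbamoyloxy in place of methyl on a saturated chain carbon, two bonds along the chain from a double-bonded ring carbon, is the first change that can be read in one place: in this assay it gives a number 0.28 log units higher from compound 3 to compound 4 (within the scatter). At this position, the entering group alone does not separate the two compounds. Compound 1 and compound 2 differ from compound 4 in more than one place, so their values cannot be assigned to carbamoyloxy alone, and no evidence bears on this result. Open, on these data alone, is whether a longer chain carrying carbamoyloxy behaves differently here. Also open, as far as these compounds go, is whether a hydroxyl or an amine in place of carbamoyloxy does, or methyl in place of the retained propyl.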